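From cyano to methylsulfonyl: compound 2 to compound 3

The compounds below may be only part of what the source reports. "The series", "measured", "known", "first", "only" and "open" are said of these compounds alone.

Among the compounds with values here, in an ADME assay on CHO cells (Cricetulus griseus) for cytotoxicity, read by MTT assay (a lower number here means that less compound is tolerated, a higher number that more compound is tolerated), compound 2 (`CN1CCN(C2CCN(c3nccc4[nH]c(-c5cccc(C#N)c5)nc34)CC2)CC1`) gives 16000 nM as the higher of the two numbers so far, and compound 1 (`CN1CCN(C2CCN(c3nccc4[nH]c(-c5ccc(F)c(F)c5)nc34)CC2)CC1`) gives 5000 nM as the lower. The step in question leads to compound 3 (`CN1CCN(C2CCN(c3nccc4[nH]c(-c5cccc(S(C)(=O)=O)c5)nc34)CC2)CC1`), with methylsulfonyl in place of cyano on an aromatic carbon. Within the data shown here, one measured step bears on this, and only indirectly: a 3.2-fold higher number from compound 1 to compound 2 (0.51 log units; beyond the scatter) is modest but beyond the scatter, and it exchanged 3,4-difluorophenyl for 3-cyanophenyl. Among the measured compounds shown here, no measured compound carries methylsulfonyl. No clear direction follows, and no change beyond the scatter is expected in this assay for this exchange. The estimate amounts to a 1.1-fold lower number from compound 2 to compound 3 (0.06 log units; within the scatter) as an expected step within the scatter. For compound 3 the expected value is 14000 nM within an estimated range from 6000 nM to 35000 nM in this assay for now.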

Compound 3, half-maximal cytotoxic concentration: > 50000 nM
Compound 3 ended at the assay's limit; the forecaster's own chance of this, stated with the estimate: 10%; middle value at least 3.5-fold (0.55 log units) from the limit.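

In this assay compound 3 stands at a limit of the assay, not at a number: the limit of > 50000 nM in this assay, at which 1 of the 3 values shown sits.

On this aromatic carbon, the exchange of cyano for methylsulfonyl gives an at least 3.1-fold higher number from compound 2 to compound 3 (0.49 log units; beyond the scatter), and the wider exchange of the whole aryl group gives an at least 10-fold higher number from compound 1 to compound 3 (1.00 log units; beyond the scatter). Read with a 3.2-fold higher number from compound 1 to compound 2 (0.51 log units; beyond the scatter), the three groups fall in one order, from 3,4-difluorophenyl through 3-cyanophenyl to 3-(methylsulfonyl)phenyl, and the change at this one place is now shown to carry the series up to the limit of this assay.

Going by these compounds, both new steps are lower bounds, so the full size of the methylsulfonyl exchange remains open. Also open, on these data alone, is whether a sulfonamide or a primary amine on the same aromatic carbon would reach the same limit.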